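Exchanging the group on the saturated ring carbon of compound 3

This account rests on a few compounds, and the source may have more. Where it says the series, first, only, none or still open, it means among the compounds named here.

Compound 1 `Cc1cc(O)c(C2=NN(c3ccc(S(N)(=O)=O)cc3)C(c3ccccc3O)C2)cc1Cl` gives 91800 nM in a functional assay on OVCAR-8 cells (Homo sapiens) for antiproliferative activity, with a stated time of 48 h; on this read-out lower numbers stand for higher toxicity in this test and higher numbers for lower toxicity in this test.
Compound 2 `Cc1cc(O)c(C2=NN(c3ccc(S(N)(=O)=O)cc3)C(c3ccccc3Cl)C2)cc1Cl` gives only a limit, > 100000 nM, in this assay.
Compound 3 `Cc1cc(O)c(C2=NN(c3ccc(S(N)(=O)=O)cc3)C(/C=C/c3ccccc3)C2)cc1Cl` gives 91700 nM in this assay.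

Compound 3 holds the lowest of the two numbers, but its nearest neighbour is compound 1, and the step of a 1.0-fold lower number from compound 1 to compound 3 (0.00 log units; within the scatter) stays within the scatter. The value of compound 2 is a limit (the limit of > 100000 nM in this assay, at which 1 of the 3 values shown sits). The step of an at least 1.0-fold lower number from compound 2 to compound 3 (0.03 log units; that floor lies within the scatter) likewise shows nothing beyond the scatter. Compound 4 `COc1ccc(C2CC(c3cc(Cl)c(C)cc3O)=NN2c2ccc(S(N)(=O)=O)cc2)cc1OC` differs from compound 3 by 3,4-dimethoxyphenyl in place of 2-phenylethenyl on a saturated ring carbon. Both measured steps that changed this same saturated ring carbon left the number essentially unmoved, so no shift beyond the scatter is expected here either, an estimated 1.0-fold lower number from compound 3 to compound 4 (0.01 log units; within the scatter). Compound 4 is therefore expected at about 90000 nM, between 40000 nM and 160000 nM.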

Compound 4, concentration lethal to 50% of the cells: > 100000 nM
Compound 4 gave a limit, no number; the forecaster's own chance of this, stated with the estimate: 40%; middle value at least 1.1-fold (0.04 log units) away from the limit.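

In this assay compound 4 gives only a limit (> 100000 nM). A dimethoxylated phenyl group on this saturated ring carbon, carrying hydrogen-bond acceptors that 2-phenylethenyl lacks, brings no readable shift in either step (an at least 1.0-fold higher number from compound 3 to compound 4 (0.03 log units; that floor lies within the scatter)) (an at least 1.0-fold higher number from compound 1 to compound 4 (0.03 log units; that floor lies within the scatter)), though these floors do not show how far the true values lie. Compound 2 and compound 4 are both limits, so the step between them cannot be read: the limit of > 100000 nM in this assay, at which 2 of the 4 values shown sit.

The compounds shown leave open whether an amine or a carboxylic acid on this carbon would lower the number. They also leave open whether any change here would move it beyond the scatter.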